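Ethoxy in place of chloro: working notes

This account rests on a few compounds, and the source may have more. Where it says the series, first, only, none or still open, it means among the compounds named here.

compound 1 `Cc1ccc([C@@H](C)Oc2cc3onc(CCC(=O)O)c3cc2Cl)nc1` – 99.7%
compound 2 `O=C(O)CCn1c(=O)oc2cc(Cl)c(Cl)cc21` – 98.2%

In an ADME assay on a cell-free system (plasma, Homo sapiens) for protein binding, compound 2 gives 98.2% and has the larger unbound fraction of the two. Compound 1 gives 99.7% and leaves less free, a gap beyond the scatter. Compound 3 `CCOc1cc2oc(=O)n(CCC(=O)O)c2cc1Cl` carries ethoxy in place of chloro on an aromatic carbon. Going by the values given here, no measured pair shows this change, so the expectation rests only on compound 2 (98.2%). A small step towards less binding in this assay, within the scatter, is expected (a 1.7-fold higher unbound fraction from compound 2 to compound 3 (0.22 log units; within the scatter)). The estimated value for compound 3 is 97% (range 93% to 98.8%).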

Compound 3, plasma protein binding: 95.8%
Estimate against measurement, compound 3: 1.4-fold (0.15 log units) (unbound fraction) below, within the range that was stated.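

Going by these compounds alone, on this aromatic carbon, ortho to a chloro group, ethoxy in place of chloro gives a 2.3-fold higher unbound fraction from compound 2 to compound 3 (0.37 log units; beyond the scatter) in this assay and provides the first single-place comparison. The position is therefore not silent in this read-out: the change leaves more of the compound free, by a modest step. No measurement shown accounts for the shift.

The compounds shown leave open how an amine or a longer alkoxy chain on this carbon would compare with ethoxy. They also leave open what replacing the remaining chloro group would do.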